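Ethyl to methyl in the series: compound 4 expected

The source may report more compounds than this note shows. Statements on the series, on what has been measured and on what is new or still open speak of the compounds shown alone.

Among the compounds with values here, compound 1 `CCc1ccc(/C=C/C(=O)c2ccc(-n3ccnc3)cc2)cc1` gives 320 nM in an assay on isolated protein for inhibition of Amine oxidase [flavin-containing] B (Homo sapiens) (on this read-out higher numbers stand for weaker inhibition and lower numbers for stronger inhibition), the highest of the two numbers measured so far. Compound 2 `CCOc1ccc(C(=O)/C=C/c2ccc(CC)cc2)cc1` gives 210 nM in this assay, and the step of a 1.5-fold lower number from compound 1 to compound 2 (0.18 log units; within the scatter) stays within the scatter. Compound 3 `O=C(/C=C/c1ccc(ON=C(c2ccccc2)c2ccccc2)cc1)c1ccc(F)cc1` is reported at < 50 nM in this assay, which is a limit of the assay and not a number; it sits at the limit of < 50 nM in this assay, at which 1 of the 3 values shown sits. Compound 4 `Cc1ccc(/C=C/C(=O)c2ccc(-n3ccnc3)cc2)cc1` differs from compound 1 by hydrogen in place of methyl on a saturated chain carbon bound to an aromatic carbon. Within the data shown here, no measured step touches this ethyl to methyl shortening: the single step from compound 1 to compound 2 exchanges ethoxy for imidazolyl, so nothing measured bears on it, and no step beyond the scatter is expected in this assay. Compound 4 is therefore estimated at 400 nM, between 150 nM and 1100 nM, the step of a 1.3-fold higher number from compound 1 to compound 4 (0.10 log units; within the scatter) expected to stay within the scatter.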

Compound 4, half-maximal inhibitory concentration: 320 nM
Compound 4: middle estimate off by 1.3-fold (0.10 log units), on the high side, and the stated range covers the measured number.
By their numbers in this assay, from the lowest: compounds 2, 1 and 4 (each within the scatter of the next). At a limit, below all of these: compound 3.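

In this assay, within the data shown here, hydrogen in place of methyl on a saturated chain carbon bound to an aromatic carbon gives no change at the digits printed from compound 1 to compound 4 (within the scatter), the only reading so far at this position. On the core of compound 1, ethyl and methyl therefore read alike, though this rests on a single pair. Nothing at hand accounts for this result.

From the compounds shown here alone, whether a longer chain such as propyl, an amine or a carboxylic acid at this position would read alike stays open. Also open, going by these compounds, is whether ethyl to methyl reads the same on the core of compound 2, which carries ethoxy in place of 1H-imidazol-1-yl.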